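Swapping a Phenyl for Bromine on an Inactive Core

The source may hold more compounds than are shown below. What is called first, only, known or untested is meant among the compounds shown, and "the series" means these compounds.

Compound 1, with structure `Cc1c(-c2ccccc2)cc(C(=O)NC2CCCCCC2)c(=O)n1Cc1ccc(F)cc1`, was tested in an assay on HEK293 cells for inhibition of Lysophosphatidylserine lipase ABHD12 (Homo sapiens), read by scintillation counting, with stated times of 30 min and 5 min; a lower number here means a stronger inhibitor, a higher number a weaker inhibitor. In this assay compound 1 gives > 10000 nM, which is a limit of the assay rather than a measured number. Its relative compound 2, `Cc1ccc(C(=O)NC2CCCCCC2)c(OCc2ccc(F)cc2)n1`, was tested as well. In this assay compound 2 gives > 10000 nM, again a limit. So compound 1 stands at the edge of what the assay can report, and the limit of > 10000 nM in this assay, at which 2 of the 2 values shown sit, shows that every value in this set sits there. Compound 3, `Cc1c(Br)cc(C(=O)NC2CCCCCC2)c(=O)n1Cc1ccc(F)cc1`, has not yet been measured. It differs from compound 1 in one place: bromo in place of phenyl on an aromatic carbon. For the measured compounds named here, with no measured step to lean on, the step that the limit leaves unreadable from compound 1 to compound 3 is expected to be small and may well stay within the usual scatter. For compound 3 the expected value in this assay is therefore 20000 nM, with a likely range from 5000 nM to 100000 nM.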

Compound 3, half-maximal inhibitory concentration: > 10000 nM
Compound 3 gave a limit, no number (the forecaster's own chance of this, stated with the estimate: 80%); the middle value lies beyond the limit too.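

In this assay, for the compounds shown here, compound 1 and compound 3 both end at a limit of the assay rather than a number, so no step between them can be read: the limit of > 10000 nM in this assay, at which 3 of the 3 values shown sit.

The compounds shown leave open how phenyl and bromo truly compare on this core, and whether any version of it inhibits the enzyme measurably.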